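Chloro Placement on the Nitrogen Ring of a Vinyl Sulfone

A few compounds are considered here, and "the series" means these few. Any claim that something is new, unique, unknown or untested is made for them only; others in the source may bear on it.

Measured compounds in an assay on U2OS cells for activation of nuclear factor erythroid 2-related factor 2 (Homo sapiens), read by chemiluminescence, with a stated time of 6 h; a higher number here means that more compound is needed for the effect, a lower number that less compound is needed:
Compound 1, `COc1ccccc1S(=O)(=O)/C=C/c1ccccc1Cl`, gives 530 nM.
Compound 2, `COc1ccccc1S(=O)(=O)/C=C/c1ccccn1`, gives 9070 nM.
Compound 3, `COc1ccccc1S(=O)(=O)/C=C/c1cccc(Cl)n1`, gives 1160 nM.

Compound 2 stands highest of the three numbers in this assay; compound 3 is nearest to it and compound 1 furthest, both beyond the scatter. Among the measured compounds shown here, only one measured pair differs in a single place: a 7.8-fold lower number from compound 2 to compound 3 (0.89 log units; beyond the scatter), a modest change but beyond the scatter. Compound 4, `COc1ccccc1S(=O)(=O)/C=C/c1ccc(Cl)cn1`, arises from compound 2 by the change (chloro in place of hydrogen on an aromatic carbon). The same group thus enters the same six-membered aromatic ring with 1 nitrogen as in compound 3, but at a different carbon, two atoms from the ring nitrogen and para to a large group. For the measured compounds named here, the step from compound 2 to compound 3 is the only direct precedent, and compound 1, which carries chloro on a ring without nitrogen, shows that every chloro-bearing compound in this set sits lower than compound 2. The new position has not been tested, so a shift in the same direction but of smaller size than that precedent is expected in this assay. Compound 4 is therefore expected to give 3000 nM, within a range of 1200 nM to 8000 nM, which means an expected step of a 3.0-fold lower number from compound 2 to compound 4 (0.48 log units; beyond the scatter).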

Compound 4, half-maximal effective concentration: 6310 nM
Compound 4: the middle estimate sits 2.1-fold (0.32 log units) below what was measured; low and high end bracket the measured number.
By their numbers in this assay, from the lowest: compound 1; then compound 3; then compounds 4 and 2 (each within the scatter of the next).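

In this assay, chloro in place of hydrogen on this aromatic carbon, two atoms from the ring nitrogen and para to a large group, gives a 1.4-fold lower number from compound 2 to compound 4 (0.16 log units; within the scatter), whereas the same exchange at the carbon of compound 3 gives a 7.8-fold lower number from compound 2 to compound 3 (0.89 log units; beyond the scatter). Chloro on this six-membered aromatic ring with 1 nitrogen therefore does not by itself set a compound apart from compound 2: among these two chloro compounds on that ring, compound 3 is set apart and compound 4 is not, so the outcome of this change depends on the carbon it occupies. Nothing measured here accounts for this difference between the two carbons.

The compounds shown leave open whether a different group on this same carbon, such as an amine, a methoxy group or a carboxylic acid, would move the number in this assay beyond the scatter from compound 2. They also leave open how chloro would behave on the other carbons of this ring, and whether any of those placements would come closer to compound 1 at 530 nM.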